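Adding an Ethoxycarbonyl Group to Compound 1

A few compounds are considered here, and "the series" means these few. Any claim that something is new, unique, unknown or untested is made for them only; others in the source may bear on it.

Measured so far in a functional assay on the whole organism (strain Wistar) for inhibition, with Rattus norvegicus as the target, read by paw edema, with stated times of 2 h and 1 h, at a dose of 6 mg/kg by the oral route; on this read-out higher numbers stand for more inhibition at the one dose given (going by the name of the read-out) and lower numbers for less inhibition:
compound 1 `O=C(CO[N+](=O)[O-])NNC(=O)c1ccc(-n2[nH]c(=O)cc2-c2ccc([N+](=O)[O-])cc2)cc1` gives 27.1%
compound 2 `O=C(CO[N+](=O)[O-])NNC(=O)c1ccc(-n2[nH]c(=O)cc2-c2ccccc2O)cc1` gives 19.3%
compound 3 `O=C(CO[N+](=O)[O-])NNC(=O)c1ccc(-n2[nH]c(=O)cc2-c2ccccc2)cc1` gives 16.1%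

Compound 1 has the highest of the three numbers. Its nearest neighbour is compound 2, reached by the step of a number 7.8 percentage points lower from compound 1 to compound 2 (within the scatter), which stays within the scatter, so the two cannot be ranked against each other. The step of a number 11 percentage points lower from compound 1 to compound 3 (beyond the scatter) is beyond the scatter and modest, so compound 1 does stand above compound 3. The step of a number 3.2 percentage points lower from compound 2 to compound 3 (within the scatter) is again within the scatter.

Compound 4 `CCOC(=O)c1c(-c2ccc([N+](=O)[O-])cc2)n(-c2ccc(C(=O)NNC(=O)CO[N+](=O)[O-])cc2)[nH]c1=O` is the next compound. It differs from compound 1 in one place: ethoxycarbonyl in place of hydrogen on an aromatic carbon. All three measured steps alter the group on the phenyl ring attached to the shared core; none of them touches the ring carbon that gains the ethoxycarbonyl group here. Within the data shown here, no measured step therefore bears on this change, and nothing in the data points to a rise or a fall beyond the scatter.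

For compound 4 the estimate is 27%, with a range from 14% to 40%, which means an expected step of a number 0.1 percentage points lower from compound 1 to compound 4 (within the scatter).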

Compound 4, a percentage reported as inhibition, in the whole organism at one dose (the size of the read-out at that dose, not a potency): 28.1%
Compound 4: the middle estimate sits 1.1 percentage points below what was measured; measured number inside the range.
By their numbers in this assay, from the lowest: compounds 3, 2, 1 and 4 (each within the scatter of the next, the first and the last beyond it).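

Among these compounds, the earlier compounds differ only in the group on the phenyl ring, so compound 4 gives the first look at this aromatic carbon of the five-membered aromatic ring, and in this assay the result of placing ethoxycarbonyl there is a number 1 percentage points higher from compound 1 to compound 4 (within the scatter) and so gives no ranking of the pair. A hydrogen can therefore give way to a group of 5 heavy atoms on this carbon, next to the ring atom that bears a 4-nitrophenyl group, and the read-out does not separate the two compounds at the one dose given. No measurement here offers an explanation for this result.

A single group at this position cannot show whether others would behave alike: a carboxylic acid, an amine, a methyl group or a longer chain on the same carbon could give a quite different number. Also open, on these data alone, is whether ethoxycarbonyl would give a similar result alongside the 2-hydroxyphenyl group of compound 2 or the unsubstituted phenyl group of compound 3, where the starting numbers are lower.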